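Thiophene in place of phenyl on the oxadiazole core

The source may hold more compounds than are shown below. What is called first, only, known or untested is meant among the compounds shown, and "the series" means these compounds.

Measured compounds:
- compound 1 `CCc1cc(-c2noc(-c3cc(C)nc(CN(C)CC(C)C)c3)n2)cc(C)c1OC[C@@H](O)CNC(=O)CO`: 0.004
- compound 2 `CCc1cc(-c2noc(-c3cc(C)cc(CN(C)C)c3)n2)cc(C)c1OC[C@@H](O)CNC(=O)CO`: 0.029
- compound 3 `CCc1cc(-c2noc(-c3ccc(CN(C)CC(C)C)c(C)c3)n2)cc(C)c1OC[C@@H](O)CNC(=O)CO`: < 0.001

In an ADME assay on a cell-free system (plasma, Rattus norvegicus, strain Wistar) for protein binding, read by LC-MS, using equilibrium dialysis, with a stated time of 6 h (on this read-out higher numbers stand for a larger free fraction and lower numbers for a smaller free fraction), compound 2 gives 0.029. Compound 1 gives 0.004 in this assay, a lower number than compound 2, and the gap between the two lies beyond the usual scatter of repeated measurements. Compound 3 is reported only as a limit in this assay, < 0.001, and no exact number is known for it (the limit of < 0.001 in this assay, at which 1 of the 3 values shown sits). Among the two numbers that are known, compound 2 therefore stands as the higher one.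

Compound 4 `CCc1cc(-c2noc(-c3cc(C)c(CN(C)C)s3)n2)cc(C)c1OC[C@@H](O)CNC(=O)CO` has not yet been measured in this assay. It differs from compound 2 in one place: 5-((dimethylamino)methyl)-4-methylthiophen-2-yl in place of 3-((dimethylamino)methyl)-5-methylphenyl on an aromatic carbon. For the measured compounds named here, no pair of measured compounds shows this kind of change, so no measured step can be pointed to for its size. Since the dimethylaminomethyl and methyl groups are kept and only the ring is exchanged, compound 4 is expected to stay close to compound 2, with a step from compound 2 to compound 4 of a 1.5-fold lower number from compound 2 to compound 4 (0.16 log units; within the scatter), within the scatter. Compound 4 is thus estimated to give 0.02 in this assay, between 0.006 and 0.06.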

Compound 4, unbound fraction: 0.012
Compound 4: the middle estimate sits 1.7-fold (0.22 log units) above what was measured; the measured number falls inside the stated range.
By their numbers in this assay, from the lowest: compound 1; then compound 4; then compound 2. At a limit, below all of these: compound 3.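

In this assay, for the compounds shown here, the exchange of 3-((dimethylamino)methyl)-5-methylphenyl for 5-((dimethylamino)methyl)-4-methylthiophen-2-yl gives a 2.4-fold lower number from compound 2 to compound 4 (0.38 log units; beyond the scatter), the first step that can be read at this position on the shared core. The earlier compounds shown here differ from one another in more than one place, so they could not separate the ring from its substituents; here the dimethylaminomethyl and methyl groups are kept, and a five-membered aromatic ring with 1 hetero atom in place of a six-membered aromatic ring of carbon only is enough to give a modest change in the free fraction. Nothing given here accounts for the size or the direction of this step.

On these data alone, it remains open whether the same ring exchange would give a step of similar size with the isobutyl(methyl)amino group carried by compound 1 in place of the dimethylamino group. Also open, as far as these compounds go, is where a thiophene bearing a morpholine or a carboxylic acid in place of that amine, or a furan or thiazole in place of the thiophene, would fall in this assay.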